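Benzoxaborole chalcones: ethyl for phenyl on the aryl ketone

The compounds below may be only part of what the source reports. "The series", "measured", "known", "first", "only" and "open" are said of these compounds alone.

Compound 1 `O=C(/C=C/c1ccc2c(c1)B(O)OC2)c1ccc(-c2ccccc2)cc1`: 9500 nM in a functional assay on HCT-116 cells (Homo sapiens) for cytotoxicity, read by MTT assay, with a stated time of 48 h; on this read-out higher numbers stand for weaker inhibition and lower numbers for stronger inhibition
Compound 2 `O=C(/C=C/c1ccc2c(c1)B(O)OC2)c1ccco1`: 24100 nM
Compound 3 `O=C(/C=C/c1ccc2c(c1)B(O)OC2)c1cccnc1`: 20500 nM

Compound 1 stands lowest of the three numbers in this assay; compound 3 and compound 2 both give higher numbers, each gap lying beyond the usual scatter. Among the compounds with values here, the only step with one change, a 1.2-fold lower number from compound 2 to compound 3 (0.07 log units; within the scatter), exchanges the ring on the carbonyl carbon and does not touch the distal phenyl, so it does not bear on the present change. Compound 4 `CCc1ccc(C(=O)/C=C/c2ccc3c(c2)B(O)OC3)cc1` differs from compound 1 by ethyl in place of phenyl on an aromatic carbon. Within the data shown here, no measured pair tests this exchange, so no direction is supported and a step of no more than the scatter is expected, a 1.3-fold higher number from compound 1 to compound 4 (0.10 log units; within the scatter). For compound 4 the expected value in this assay is 12000 nM, within 5000 nM to 30000 nM.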

Compound 4, half-maximal inhibitory concentration: 10900 nM
Beside the measured number, compound 4's estimate is 1.1-fold (0.04 log units) above it; measured number inside the range.
By their numbers in this assay, from the lowest: compounds 1, 4, 3 and 2 (each within the scatter of the next, the first and the last beyond it).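

In this assay, the exchange on this aromatic carbon gives a 1.1-fold higher number from compound 1 to compound 4 (0.06 log units; within the scatter), a step within the scatter. At this position, then, the six-membered aromatic ring of the phenyl group is not needed to keep the number in the range of compound 1, at least with ethyl as the replacement. Nothing measured on these compounds offers an explanation for this result.

Open, on these data alone, is whether an amine or a carboxylic acid on this carbon would leave the number unchanged. A longer chain, such as hexyl, also remains to be compared with ethyl.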